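The source may hold more compounds than are shown below. What is called first, only, known or untested is meant among the compounds shown, and "the series" means these compounds.

Compound 1 `Cc1ccc(S(=O)(=O)OCCCc2cn(-c3ccc(C(F)(F)F)cc3)nn2)cc1`: > 100000 nM, a limit
Compound 2 `COC(=O)c1ccc(-n2cc(CCCOS(=O)(=O)c3ccc(C)cc3)nn2)cc1`: > 100000 nM, a limit
Compound 3 `COc1ccc(-n2cc(CCCOS(=O)(=O)c3ccc(C)cc3)nn2)cc1`: 74600 nM

Among the compounds with values here, in a functional assay on A549 cells (Homo sapiens) for cytotoxicity, read by MTT assay, with a stated time of 48 h (on this read-out lower numbers stand for stronger inhibition and higher numbers for weaker inhibition), compound 3 gives 74600 nM, the only actual number in this small set. Everything else measured here is the limit of > 100000 nM in this assay, at which 2 of the 3 values shown sit. The steps to compound 3 are an at least 1.3-fold lower number from compound 1 to compound 3 (0.12 log units; that floor lies within the scatter) and an at least 1.3-fold lower number from compound 2 to compound 3 (0.12 log units; that floor lies within the scatter), so the data do not firmly separate it from the other two compounds. The remaining step, a step that the two limits leave unreadable from compound 1 to compound 2, adds nothing.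

Compound 4 `Cc1ccc(S(=O)(=O)OCCCc2cn(-c3cccc(C#N)c3)nn2)cc1` has not yet been measured. It keeps the shared core, but on an aromatic nitrogen 3-cyanophenyl stands in place of 4-methoxyphenyl: 3-cyanophenyl in place of 4-methoxyphenyl on an aromatic nitrogen. The two steps to compound 3 are the relevant ones, as each exchanges another group for the methoxy-bearing one, yet neither shows a change beyond the scatter. Within the data shown here, no measured compound carries a nitrile, so this evidence is thin. Compound 4 is therefore expected to stay weak in this assay, and a report of only a limit would be no surprise. The estimated change is a 1.2-fold higher number from compound 3 to compound 4 (0.08 log units; within the scatter), a small drift towards higher numbers and nothing beyond the scatter. For compound 4 the expected value is 90000 nM, within an estimated range of 45000 nM to 180000 nM.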

Compound 4, half-maximal inhibitory concentration: > 100000 nM
Compound 4: a limit, no number (the forecaster's own chance of this, stated with the estimate: 50%); middle value at least 1.1-fold (0.04 log units) away from the limit.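

In this assay compound 4 gives > 100000 nM, which is a limit of the assay and not a number. Within the data shown here, the exchange on the aromatic nitrogen, 3-cyanophenyl in place of 4-methoxyphenyl, reads as an at least 1.3-fold higher number from compound 3 to compound 4 (0.12 log units; that floor lies within the scatter), so a nitrile, absent from the earlier compounds, is not firmly separated from the methoxy-bearing compound. This position has now carried rings with trifluoromethyl, methoxycarbonyl, methoxy and nitrile groups, yet compound 3 alone gives a number, and the set gathers at one ceiling: the limit of > 100000 nM in this assay, at which 3 of the 4 values shown sit.

As far as these compounds go, the steps between compounds resting on that limit cannot be read, so how far apart compound 1, compound 2 and compound 4 truly lie stays open. Also open, from the compounds shown here alone, is whether an amine or a carboxylic acid on that aromatic ring, or a longer chain in place of the one in the shared core, would give a number well under that of compound 3, 74600 nM.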